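The source may hold more compounds than are shown below. What is called first, only, known or untested is meant among the compounds shown, and "the series" means these compounds.

Measured compounds in an ADME assay on HEK293 cells (Homo sapiens) for cytotoxicity, read by CellTiter-Glo and resazurin assay, with a stated time of 72 h; a higher number here means that more compound is needed for the effect, a lower number that less compound is needed:

- compound 1 `COc1cccc(-c2ccc(C(=O)N(Cc3cccc(OCCCCCC(=O)O)c3)C(C)C)cc2)c1` — compound 1 gives > 20900 nM, a limit of the assay.
- compound 2 `CC(C)N(Cc1cccc(OCCCCCC(=O)O)c1)C(=O)c1ccc(-c2cccc(F)c2)cc1` — compound 2 gives > 26000 nM, also a limit.
- compound 3 `CC(C)N(Cc1cccc(OCCCCCC(=O)O)c1)C(=O)c1ccc(-c2cccc(Br)c2)cc1` — compound 3 gives > 26000 nM, again a limit.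

Compound 3 therefore stands at the limit of > 26000 nM in this assay, at which 2 of the 3 values shown sit, and none of the three compounds gives a number in this assay; the other two values are the limit of > 20900 nM in this assay, at which 1 of the 3 values shown sits, and (the limit of > 26000 nM in this assay, at which 2 of the 3 values shown sit). The steps among them, a step that the two limits leave unreadable from compound 1 to compound 2, a step that the two limits leave unreadable from compound 1 to compound 3 and a step that the two limits leave unreadable from compound 2 to compound 3, are all unreadable, since both ends of each step are limits.

Compound 4 `CC(C)N(Cc1cccc(OCCCCCC(=O)O)c1)C(=O)c1ccc(-c2ccc(Cl)c(Cl)c2)cc1` is not yet measured. It differs from compound 3 in one place: 3,4-dichlorophenyl in place of 3-bromophenyl on an aromatic carbon. For the measured compounds named here, no measured step bears on this change in a readable way, so no direction or size can be drawn from them; all that the measured compounds show is that none reached a half-maximal effect within the tested range.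

For compound 4 the expected result in this assay is again a limit rather than a number, with an estimated value of 26000 nM in a range from 13000 nM to 60000 nM. The expected step from compound 3 is a number no higher from compound 3 to compound 4 (the limit leaves the size open), meaning no change beyond the scatter.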

Compound 4, half-maximal effective concentration: > 26000 nM
Compound 4: a limit, no number (the forecaster's own chance of this, stated with the estimate: 85%); the middle value lies on the limit itself.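

In this assay compound 4 gives > 26000 nM, which is a limit and not a number. For the compounds shown here, compound 1, compound 2 and compound 3 also give limits, so no step to compound 4 can be read. On these data alone, what stays open is whether changing these groups alters the concentration needed for the effect.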